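This account rests on a few compounds, and the source may have more. Where it says the series, first, only, none or still open, it means among the compounds named here.

Measured so far in a functional assay on COLO 320 cells (Homo sapiens) for cytotoxicity, read by MTT assay, with a stated time of 4 h; a higher number here means a weaker inhibitor, a lower number a stronger inhibitor:
- Compound 1 `CCC(=O)OC[C@H]1O[C@@H](O[C@@H]2OC=C(C(=O)OC)[C@H]3C[C@H](OC(C)=O)[C@H](C)[C@@H]23)[C@H](OC(C)=O)[C@@H](OC(C)=O)[C@@H]1OC(C)=O`: 0.85 ug/mL
- Compound 2 `CCCCCCCCCCCCCC(=O)OC[C@H]1O[C@@H](O[C@@H]2OC=C(C(=O)OC)[C@H]3C[C@H](OC(C)=O)[C@H](C)[C@@H]23)[C@H](OC(C)=O)[C@@H](OC(C)=O)[C@@H]1OC(C)=O`: 30 ug/mL

Compound 1 holds the lower of the two numbers, which makes it the stronger inhibitor of this pair. The next compound to be tested is compound 3 `C=CC(=O)OC[C@H]1O[C@@H](O[C@@H]2OC=C(C(=O)OC)[C@H]3C[C@H](OC(C)=O)[C@H](C)[C@@H]23)[C@H](OC(C)=O)[C@@H](OC(C)=O)[C@@H]1OC(C)=O`. It keeps the core of compound 1 and changes only the end of one ester: vinyl in place of ethyl on a carbonyl carbon. In words, vinyl takes the place of ethyl on a carbonyl carbon, turning propanoyl into vinylcarbonyl.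

For the measured compounds named here, only one measured step bears on this change. That step, a 35-fold higher number from compound 1 to compound 2 (1.55 log units; beyond the scatter), came with undecyl in place of hydrogen on a saturated chain carbon, two bonds along the chain from a carbonyl carbon. It shows that a large extension there can weaken the result in this assay. Going by the values given here, compound 3 carries no such extension, and no measured compound yet has a vinyl group, so the data offer no direct guide. No step beyond the usual scatter is therefore expected, and the estimated change is a 1.1-fold lower number from compound 1 to compound 3 (0.03 log units; within the scatter). For compound 3 the estimated value is 0.8 ug/mL, with an expected range from 0.25 ug/mL to 2.5 ug/mL.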

Compound 3, half-maximal inhibitory concentration: "not active" (no number reported)
Compound 3 has no reported number here; no gap can be computed for the estimate.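

For the compounds shown here, compound 3 is reported as "not active" in this assay with no number, so no step from compound 1 to compound 3 can be read. No measurement shown here accounts for this result. The compounds shown leave open how far vinyl in place of ethyl on a carbonyl carbon moves the number in this assay.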